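Phenyl for Methyl at a Thioester Carbonyl

A few compounds are considered here, and "the series" means these few. Any claim that something is new, unique, unknown or untested is made for them only; others in the source may bear on it.

Measured compounds:
compound 1 `CCOC(=O)[C@@H](N)CCC(=O)NCCSC(C)=O`: 0.167 h
compound 2 `CCCOC(=O)[C@@H](N)CCC(=O)NCCSC(C)=O`: 0.167 h

In an ADME assay on isolated protein for metabolic stability, with Cocaine esterase (Homo sapiens) as the target (a higher number here means that the compound lasts longer, a lower number that the compound disappears faster), compound 1 gives 0.167 h. Compound 2 gives 0.167 h, so compound 1 stands level with it. For the measured compounds named here, the one measured step, no change at the digits printed from compound 1 to compound 2 (within the scatter), concerns methyl in place of hydrogen on a saturated chain carbon, two bonds along the chain from an oxygen next to a carbonyl group; it does not touch the carbonyl carbon whose other neighbour is sulfur. Compound 3 `CCOC(=O)[C@@H](N)CCC(=O)NCCSC(=O)c1ccccc1` differs from compound 1 by phenyl in place of methyl on a carbonyl carbon. Going by the values given here, no measured step bears on this change, so the expectation is an uncertain, modest step, a 1.5-fold higher number from compound 1 to compound 3 (0.18 log units; within the scatter), in this assay. Compound 3 is estimated at 0.25 h, between 0.08 h and 1 h.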

Compound 3, half-life in the Cocaine esterase assay: 0.167 h
Compound 3: middle estimate off by 1.5-fold (0.18 log units), on the high side; the measured number falls inside the stated range.
By their numbers in the Cocaine esterase assay, from the lowest: compounds 1, 2 and 3 (each within the scatter of the next).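

In the Cocaine esterase assay, phenyl in place of methyl on a carbonyl carbon, a place the earlier step did not touch, gives no change at the digits printed from compound 1 to compound 3 (within the scatter) and so brings a ring onto this carbon without separating the two compounds on this read-out. In a physicochemical assay for lipophilicity, measured as octanol-water partition, at pH 2 (on this read-out higher numbers stand for higher lipophilicity and lower numbers for lower lipophilicity), compound 1 gives 0.11 and compound 3 gives 1.09, a separation the half-life does not share. Lipophilicity thus moves with this change while the half-life stays level: the measured partition coefficient of compound 1, 0.11, and of compound 3, 1.09, a number 0.98 log units higher (beyond the scatter).

The compounds shown leave open whether an amine or a carboxylic acid on the phenyl ring would keep the number in the Cocaine esterase assay level.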